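A few compounds are considered here, and "the series" means these few. Any claim that something is new, unique, unknown or untested is made for them only; others in the source may bear on it.

Measured so far, in a functional assay on PC-3 cells (Homo sapiens) for cytotoxicity, read by MTT assay, with a stated time of 48 h; on this read-out lower numbers stand for stronger inhibition and higher numbers for weaker inhibition:
compound 1 `COc1cc(-c2nnc3n2NC(c2ccco2)C(C(=O)c2cccc(Br)c2)S3)cc(OC)c1OC`, 63900 nM
compound 2 `COc1cc(-c2nnc3n2NC(c2ccco2)C(C(=O)c2ccc(-c4ccccc4)cc2)S3)cc(OC)c1OC`, 45900 nM

Compound 2 stands at the lowest of the two numbers; as the step of a 1.4-fold lower number from compound 1 to compound 2 (0.14 log units; within the scatter) is within the scatter, the two are not told apart. Compound 3 `COc1cccc(C(=O)C2Sc3nnc(-c4cc(OC)c(OC)c(OC)c4)n3NC2c2ccco2)c1` differs from compound 2 by 3-methoxyphenyl in place of 4-phenylphenyl on a carbonyl carbon. Going by the values given here, the only measured step that bears on this change is a 1.4-fold lower number from compound 1 to compound 2 (0.14 log units; within the scatter), which also swapped the substituent on the same carbonyl carbon and did not leave the scatter. The step of a 1.1-fold higher number from compound 2 to compound 3 (0.04 log units; within the scatter) is therefore expected to stay within the scatter. Compound 3 is estimated at 50000 nM, with a range of 20000 nM to 120000 nM.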

Compound 3, half-maximal inhibitory concentration: 84600 nM
Estimate against measurement, compound 3: 1.7-fold (0.23 log units) below; the range from low to high includes it.
By their numbers in this assay, from the lowest: compounds 2, 1 and 3 (each within the scatter of the next).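

In this assay, 3-methoxyphenyl in place of 4-phenylphenyl on a carbonyl carbon gives a 1.8-fold higher number from compound 2 to compound 3 (0.27 log units; within the scatter), so removing the second aromatic ring and introducing a methoxy oxygen does not take the number beyond the scatter. Methoxy in place of bromo on an aromatic carbon gives a 1.3-fold higher number from compound 1 to compound 3 (0.12 log units; within the scatter), which leaves all three substituents at this position not told apart. No measured evidence bears on the reason for these results.

On these data alone, it remains open whether any group at this position can move the number beyond the scatter, for example an amine or a carboxylic acid in place of the methoxy. As far as these compounds go, whether the same flat picture holds on other cell lines also remains open.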